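A few compounds are considered here, and "the series" means these few. Any claim that something is new, unique, unknown or untested is made for them only; others in the source may bear on it.

Two measured compounds set the frame. Compound 1 `S=C(N/N=C/c1ccc(Oc2ccc3ccccc3c2)cc1)Nc1ccc(Cl)cc1` is the more lipophilic of the pair: in a physicochemical assay for lipophilicity, in phosphate buffer, measured as octanol-water partition, with a stated time of 24 h (a lower number here means a more polar compound, a higher number a more lipophilic compound), compound 1 gives 6.96. Compound 2 `S=C(N/N=C/c1ccc(Oc2ccc(Cl)cc2)cc1)Nc1ccccc1` stands lowest of the two numbers seen so far; in this assay compound 2 gives 5.52, a gap to compound 1 that lies well beyond the scatter of repeated measurements.

The not yet measured compound 3 `Cc1cc(Oc2ccc(/C=N/NC(=S)Nc3ccccc3)cc2)ccc1Cl` differs from compound 2 in a single place: methyl in place of hydrogen on an aromatic carbon. Put plainly, a methyl takes the place of a hydrogen on an aromatic carbon. No measured pair shows this exact change, so there is no shown step to lean on.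

The expectation is a modest rise in this assay, just past the scatter, with the estimated step from compound 2 to compound 3 being a number 0.48 log units higher from compound 2 to compound 3 (beyond the scatter). Compound 3 is estimated at 6, expected to fall between 5.6 and 6.5.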

Compound 3, partition coefficient: 6.03
The estimate for compound 3 lay 0.03 log units below the measured number; measured number inside the range.
By their numbers in this assay, from the lowest: compound 2; then compound 3; then compound 1.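

In this assay, replacing a hydrogen with a methyl, which turns the 4-chlorophenyl part of compound 2 into the 4-chloro-3-methylphenyl part of compound 3, gives a number 0.51 log units higher from compound 2 to compound 3 (beyond the scatter). Among these compounds, this is the first direct reading of a single change, and it shows that one added carbon at this place, ortho to a chloro group and meta to a large group, moves the number by more than repeat measurements would. No measurement shown here explains why the step has this size.

This single pair cannot show whether a methyl on another carbon of this ring would give a similar step. It also leaves open how an ethyl, a methoxy, an amine or a carboxylic acid at this same place would compare.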